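Fibroblast cytotoxicity notes on a three-compound series

The compounds below may be only part of what the source reports. "The series", "measured", "known", "first", "only" and "open" are said of these compounds alone.

Compound 1 `O=C1O[C@H]([C@@H](O)Cn2cc(-c3cc(F)cc(F)c3)nn2)C(OCc2ccccc2)=C1OCc1ccccc1` was run in an ADME assay on HFF cells (Homo sapiens) for cytotoxicity, read by MTT assay, with a stated time of 72 h; on this read-out lower numbers stand for stronger inhibition and higher numbers for weaker inhibition. In this assay compound 1 gives > 100000 nM, which is a limit of the assay and not a number. Compound 2 `O=C1O[C@H]([C@@H](O)Cn2cc(-c3cc(C(F)(F)F)cc(C(F)(F)F)c3)nn2)C(OCc2ccccc2)=C1OCc1ccccc1` is the other measured member of the set; in this assay compound 2 gives 80700 nM, a number close to the top of the tested range. Where compound 1 stands is therefore known only as a ceiling: the limit of > 100000 nM in this assay, at which 1 of the 2 values shown sits. Both measured values thus lie at or near the upper end of the scale, and neither points to marked cytotoxicity.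

Compound 3 `O=C1O[C@H]([C@@H](O)Cn2ccnn2)C(OCc2ccccc2)=C1OCc1ccccc1` has not yet been measured. It differs from compound 1 by hydrogen in place of 3,5-difluorophenyl on an aromatic carbon. Among the compounds with values here, no step between measured compounds is available, so the expectation rests on the two values alone. In this assay compound 3 is expected to give 150000 nM, with a range from 60000 nM to 400000 nM, and most likely to be reported once more as a limit rather than a number. The step expected from compound 1 to compound 3 is a step that the limit leaves unreadable from compound 1 to compound 3, which is no change beyond the scatter.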

Compound 3, half-maximal inhibitory concentration: 610 nM
Beside the measured number, compound 3's estimate is 250-fold (2.39 log units) above it, outside the stated range (below it).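

Placing hydrogen on this aromatic carbon in place of 3,5-difluorophenyl gives, in this assay, an at least 160-fold lower number from compound 1 to compound 3 (2.21 log units; beyond the scatter). With both earlier compounds carrying a substituted phenyl group here, the position had looked silent, but compound 3 shows that this substituent has a strong bearing on the fibroblast read-out, and with hydrogen in place compound 3 gives 610 nM, well away from the top of the scale. Compound 1 stands at a limit of the assay and not at a number, so the step has a floor but no measured size, because its starting point is only this: the limit of > 100000 nM in this assay, at which 1 of the 3 values shown sits.

The compounds shown leave open whether the low number needs hydrogen itself or would survive a small group on the same carbon, such as methyl, an amine or an unsubstituted phenyl ring. They also leave open whether the step holds when the core changes, for instance with a free hydroxyl in place of each benzyl ether.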